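The source may report more compounds than this note shows. Statements on the series, on what has been measured and on what is new or still open speak of the compounds shown alone.

Measured in a functional assay on the whole organism with Rattus norvegicus as the target; a lower number here means that less compound is needed, a higher number that more compound is needed for the effect:
- compound 1 `COC(=O)CC/C=C\CC[C@H]1C(=O)C[C@@H](O)[C@@H]1/C=C/CC(C)(O)CCC1CCCC1`: 1.31 mg/kg
- compound 2 `COC(=O)CC/C=C\CC[C@H]1C(=O)C[C@@H](O)[C@@H]1/C=C/CC(C)(O)CCC1CC1`: 0.273 mg/kg
- compound 3 `COC(=O)CC/C=C\CC[C@H]1C(=O)C[C@@H](O)[C@@H]1/C=C/C[C@@](C)(O)/C=C/C1CCCC1`: 1.95 mg/kg

Of these three, compound 2 gives the lowest number, and its steps to both of the others lie beyond the scatter. The next compound for this assay is compound 4 `COC(=O)CC/C=C\CC[C@H]1C(=O)C[C@@H](O)[C@@H]1/C=C/CC(C)(O)CCC1=CCCC1`, which departs from compound 2 as follows: cyclopent-1-en-1-yl in place of cyclopropyl on a saturated chain carbon, three bonds along the chain from an oxygen on a saturated carbon. The ring therefore changes on a saturated chain carbon, three bonds along the chain from an oxygen on a saturated carbon.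

Among the compounds with values here, the closest precedent is a 4.8-fold lower number from compound 1 to compound 2 (0.68 log units; beyond the scatter). It involves the same place and a saturated five-membered ring, and read backwards it points to a higher number on leaving cyclopropyl. The step of a 7.1-fold higher number from compound 2 to compound 3 (0.85 log units; beyond the scatter) also leaves cyclopropyl and goes the same way, although compound 3 differs in its chain as well. The step of a 1.5-fold higher number from compound 1 to compound 3 (0.17 log units; within the scatter) stays within the scatter, but it concerns a chain double bond and not one in the ring. Within the data shown here, no measured compound carries cyclopent-1-en-1-yl, so the effect of the ring double bond remains open. A rise of modest size is expected, with the result lying near compound 1, and the expected step is a 3.7-fold higher number from compound 2 to compound 4 (0.56 log units; beyond the scatter). For compound 4 the estimate is 1 mg/kg, with an expected range of 0.4 mg/kg to 2.6 mg/kg.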

Compound 4, dose for half-maximal effect: 1.18 mg/kg
Estimate against measurement, compound 4: 1.2-fold (0.07 log units) below; the range from low to high includes it.
By their numbers in this assay, from the lowest: compound 2; then compounds 4, 1 and 3 (each within the scatter of the next).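

In this assay, the step of a 4.3-fold higher number from compound 2 to compound 4 (0.64 log units; beyond the scatter) lies beyond the scatter, so at this place, on a saturated chain carbon, three bonds along the chain from an oxygen on a saturated carbon, the unsaturated five-membered ring joins the saturated one in departing from cyclopropyl. The ring double bond itself makes no readable difference, since the step of a 1.1-fold lower number from compound 1 to compound 4 (0.05 log units; within the scatter) stays within the scatter, and cyclopent-1-en-1-yl and cyclopentyl cannot be told apart in this assay on this pair. The step of a 1.7-fold lower number from compound 3 to compound 4 (0.22 log units; within the scatter) is also within the scatter, although these two compounds differ in the chain double bond as well as in the ring, so a double bond in the ring and one in the chain give no separable readings here.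

No independent data bear on why cyclopropyl stands apart from the five-membered rings. Still open, from the compounds shown here alone, is whether cyclobutyl, a phenyl ring or an open butyl chain at this place would read with cyclopropyl or with the five-membered rings, and whether the cyclopropyl result would survive a chain double bond like that of compound 3.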